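The source may report more compounds than this note shows. Statements on the series, on what has been measured and on what is new or still open speak of the compounds shown alone.

Compound 2 `COc1ccc(Nc2nc(SCc3ccc(C(F)(F)F)cc3)nc3ccccc23)cc1OC` carries a 3,4-dimethoxyphenyl group on the shared core. In a functional assay on PC-3 cells (Homo sapiens) for cytotoxicity, read by MTT assay, with a stated time of 72 h (a higher number here means a weaker inhibitor, a lower number a stronger inhibitor), compound 2 gives 14100 nM. Among the measured compounds shown here, the only other measured compound, compound 1 `O=[N+]([O-])c1cccc(Nc2nc(SCc3ccc(C(F)(F)F)cc3)nc3ccccc23)c1`, gives 13500 nM in this assay, so the two numbers lie within the scatter of each other and neither can be called stronger.

Compound 3 `Fc1ccc(Nc2nc(SCc3ccc(C(F)(F)F)cc3)nc3ccccc23)cc1Cl` has not yet been measured. The change from compound 2 is 3-chloro-4-fluorophenyl in place of 3,4-dimethoxyphenyl on a nitrogen on an aromatic ring. For the measured compounds named here, the one measured step at this same place, a 1.0-fold higher number from compound 1 to compound 2 (0.02 log units; within the scatter), swapped one aromatic group for another without moving the number beyond the scatter. Going by the values given here, that single step is the only guide, and it suggests that the shared core, not the group on the nitrogen, sets the read-out here. Compound 3 is therefore expected to sit close to compound 2, with a step of a 1.0-fold lower number from compound 2 to compound 3 (0.00 log units; within the scatter). The estimate for compound 3 in this assay is 14000 nM, within a range from 5000 nM to 40000 nM.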

Compound 3, half-maximal inhibitory concentration: 18600 nM
Compound 3: the middle estimate sits 1.3-fold (0.12 log units) below what was measured; the range from low to high includes it.
By their numbers in this assay, from the lowest: compounds 1, 2 and 3 (each within the scatter of the next).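

With a third aromatic group on the nitrogen, this assay shows a 1.3-fold higher number from compound 2 to compound 3 (0.12 log units; within the scatter) and also a 1.4-fold higher number from compound 1 to compound 3 (0.14 log units; within the scatter) in this comparison, so the 3-chloro-4-fluorophenyl group cannot be told apart from either earlier group. Until now the only comparison at this position was between two rings carrying oxygen-bearing groups, whereas this ring carries chlorine and fluorine instead, and the number still stays within the scatter, with no listed compound going against this. No measurement shown here offers an explanation for this sameness.

On these data alone, all three groups on the nitrogen are substituted phenyl rings, so it remains open whether a saturated ring such as morpholine, a short alkyl chain or a phenyl ring bearing a carboxylic acid would give a similar number. The compounds shown also leave open how much the rest of the shared core contributes, since it is identical in all of them.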